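Halogen Changes in a Shared Core

The source may hold more compounds than are shown below. What is called first, only, known or untested is meant among the compounds shown, and "the series" means these compounds.

Three analogues of one core have been measured. Compound 1 `O=S(=O)(c1ccccc1)c1nc2ccccc2nc1Nc1ccc(F)cc1` gives 5190 nM in a functional assay on HCT-116 cells (Homo sapiens) for cytotoxicity, read by MTT assay, with a stated time of 72 h; on this read-out lower numbers stand for stronger inhibition and higher numbers for weaker inhibition. Compound 2 `O=S(=O)(c1ccccc1)c1nc2ccccc2nc1Nc1ccc(Cl)cc1` differs from it by chloro in place of fluoro on an aromatic carbon and gives 2000 nM in this assay, a step of a 2.6-fold lower number from compound 1 to compound 2 (0.41 log units; beyond the scatter). Compound 3 `O=S(=O)(c1ccc(Br)cc1)c1nc2ccccc2nc1Nc1ccc(F)cc1` differs from compound 1 by bromo in place of hydrogen on an aromatic carbon; in this assay compound 3 gives 1670 nM, a step of a 3.1-fold lower number from compound 1 to compound 3 (0.49 log units; beyond the scatter). The numbers for compound 2 and compound 3 lie within the scatter of each other. Compound 4 `O=S(=O)(c1ccc(Br)cc1)c1nc2ccccc2nc1Nc1ccc(Cl)cc1` has not been measured. It differs from compound 3 by chloro in place of fluoro on an aromatic carbon, the same change as that between compound 1 and compound 2. Because a 2.6-fold lower number from compound 1 to compound 2 (0.41 log units; beyond the scatter) was modest, a step of similar size is expected for compound 4, a 2.2-fold lower number from compound 3 to compound 4 (0.35 log units; beyond the scatter), although this rests on a single pair. Compound 4 is accordingly estimated at 750 nM, between 350 nM and 1700 nM.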

Compound 4, half-maximal inhibitory concentration: 10600 nM
Beside the measured number, compound 4's estimate is 14-fold (1.15 log units) below it; the measured number lies above the stated range.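

The change of fluoro to chloro did not carry over between cores, giving a 6.3-fold higher number from compound 3 to compound 4 (0.80 log units; beyond the scatter), opposite in direction to the earlier step: the same change on two cores in this assay, a 2.6-fold lower number (0.41 log units; beyond the scatter) from compound 1 to compound 2 and a 6.3-fold higher number (0.80 log units; beyond the scatter) from compound 3 to compound 4, 16-fold (1.22 log units) apart, beyond the scatter of two such steps. Bromo in place of hydrogen reversed in the same way, giving a 5.3-fold higher number from compound 2 to compound 4 (0.72 log units; beyond the scatter): the same change on two cores in this assay, a 3.1-fold lower number (0.49 log units; beyond the scatter) from compound 1 to compound 3 and a 5.3-fold higher number (0.72 log units; beyond the scatter) from compound 2 to compound 4, 16-fold (1.22 log units) apart, beyond the scatter of two such steps. These four compounds show that neither change can be carried from one core to the other as a fixed step and that the two steps do not add, but they do not show why the direction reverses or which direction would hold on a further core.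

The compounds shown leave open whether a methoxy group, a nitrile or an amine in place of the chloro or the bromo would also reverse direction between cores.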